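The source may hold more compounds than are shown below. What is called first, only, known or untested is meant among the compounds shown, and "the series" means these compounds.

Measured in a functional assay on SiHa cells (Homo sapiens) for inhibition, read by CCK-8 assay, with a stated time of 72 h, tested at 10 uM; on this read-out higher numbers stand for more inhibition of growth at the one concentration tested and lower numbers for less inhibition of growth:
Compound 1 `CN(C)C(=O)c1cc2cnc(Nc3ccc(NC(=O)C4(C(=O)Nc5ccccc5F)CC4)cc3)nc2n1C1CCCC1`: 103%
Compound 2 `CN(C)C(=O)c1cc2cnc(Nc3ccc(NC(=O)C4(C(=O)Nc5ccc(Cl)c(C(F)(F)F)c5)CC4)cc3)nc2n1C1CCCC1`: 61.1%

Of these two, compound 2 stands lower at 61.1%, and the gap to compound 1 is beyond the scatter. Compound 3 `Cc1ccc(NC(=O)C2(C(=O)Nc3ccc(Nc4ncc5cc(C(=O)N(C)C)n(C6CCCC6)c5n4)cc3)CC2)cc1` has the same core and differs from compound 2 as follows: 4-methylphenyl in place of 4-chloro-3-(trifluoromethyl)phenyl on an amide-type nitrogen. In words, it carries 4-methylphenyl in place of 4-chloro-3-(trifluoromethyl)phenyl on an amide-type nitrogen.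

For the measured compounds named here, one measured step bears on this change, a number 41.9 percentage points lower from compound 1 to compound 2 (beyond the scatter). It is large, and it replaced a different group on that same nitrogen. Going by the values given here, with only that step as a guide, a rise in this assay is expected, probably smaller than the full size of that step, since 4-methylphenyl is not 2-fluorophenyl. The expected change is a number 23.9 percentage points higher from compound 2 to compound 3 (beyond the scatter). For compound 3 the estimated value is 85%, with an expected range from 62% to 108%.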

Compound 3, percent growth inhibition at one concentration: 104%
The estimate for compound 3 lay 19 percentage points below the measured number, and the stated range covers the measured number.
By their numbers in this assay, from the lowest: compound 2; then compounds 1 and 3 (each within the scatter of the next).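

On this amide-type nitrogen in this assay, 4-methylphenyl in place of 4-chloro-3-(trifluoromethyl)phenyl gives a number 42.9 percentage points higher from compound 2 to compound 3 (beyond the scatter), so among the three compounds the low number goes with that one group and not with every substituted phenyl placed there. With 4-methylphenyl in place of 2-fluorophenyl the result is a number 1 percentage points higher from compound 1 to compound 3 (within the scatter), so these two groups cannot be told apart on this read-out, although they carry different substituents. No supporting data are at hand to say why 4-chloro-3-(trifluoromethyl)phenyl stands apart.

The compounds shown do not separate the chlorine from the trifluoromethyl, which leave together, and a phenyl group carrying only one of them would address that. They also leave open whether this nitrogen needs an aromatic ring at all, a question that a cyclohexyl group or a short alkyl chain would address.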